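The source may hold more compounds than are shown below. What is called first, only, known or untested is meant among the compounds shown, and "the series" means these compounds.

Working notes on the series. Of the compounds shown here, three have been measured in an ADME assay on HEp-2 cells (Homo sapiens) for cytotoxicity, read by CCK-8 assay, with a stated time of 6 days; a higher number here means that more compound is tolerated, a lower number that less compound is tolerated; a fourth is yet to be placed. Compound 1 `O=c1n(Cc2nc3ccc(C(F)(F)F)cn3c2CCCCO)c2cnccc2n1C1CC1` returns a limit of the assay rather than a number, > 100000 nM. Compound 2 `O=c1n(Cc2nc3cc(C(F)(F)F)ccn3c2CCCCO)c2cnccc2n1C1CC1` likewise returns a limit, > 100000 nM. Compound 3 `O=C(O)c1c(Cn2c(=O)n(C3CC3)c3ccncc32)nc2cc(Cl)ccn12`, which carries a carboxy group on the shared core, also returns a limit, > 100000 nM. Compound 3 therefore stands where everything measured so far sits: the limit of > 100000 nM in this assay, at which 3 of the 3 values shown sit. For the measured compounds named here, no number separates it from compound 1 or compound 2, and no step between measured compounds can be sized. Compound 4 `CCCCNc1c(Cn2c(=O)n(C3CC3)c3ccncc32)nc2cc(Cl)ccn12` differs from compound 3 in one place: butylamino in place of carboxy on an aromatic carbon. Going by the values given here, no measured step covers such a change, so the series gives no direction for it. The expected step is a number no higher from compound 3 to compound 4 (the limit leaves the size open), which amounts to no change beyond the scatter, with a fall into the measurable range left possible. For compound 4 the estimate in this assay is 100000 nM, with a range from 30000 nM to 300000 nM.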

Compound 4, half-maximal cytotoxic concentration: > 100000 nM
Compound 4: no number, only a limit; the forecaster's own chance of this, stated with the estimate: 65%; the middle value sits exactly at the limit.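

No step from compound 3 to compound 4 can be read in this assay, since each returns only a limit and no number: the limit of > 100000 nM in this assay, at which 4 of the 4 values shown sit.

The compounds shown leave open how far butylamino in place of carboxy moves the value, and whether any compound of the series gives a measurable number in this assay.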